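Adding a Second Chloro to the Core of Compound 1

This account rests on a few compounds, and the source may have more. Where it says the series, first, only, none or still open, it means among the compounds named here.

Three measured compounds share a core in which a chloromethyl-substituted benzyl group is attached to a fused bicyclic system. In a functional assay on UACC-62 cells (Homo sapiens) for cytotoxicity, read by sulforhodamine B assay, with a stated time of 48 h (on this read-out lower numbers stand for stronger inhibition of growth and higher numbers for weaker inhibition of growth), compound 1 `ClCc1cccc(Cn2cnc3ncnc(Cl)c32)c1` gives 2180 nM, compound 2 `ClCc1cccc(Cn2cnc3c(Cl)ncnc32)c1` gives 1820 nM, and compound 3 `ClCc1cccc(Cn2cnc3c(Cl)nc(Cl)nc32)c1` gives 1860 nM. Compound 1 is not separable from the other two on these numbers, its gaps to compound 3 and to compound 2 both falling within the usual scatter of this assay. The unmeasured compound 4 `ClCc1cccc(Cn2cnc3nc(Cl)nc(Cl)c32)c1` differs from compound 1 by chloro in place of hydrogen on an aromatic carbon. Among the measured compounds shown here, the one measured step of the same kind, chloro in place of hydrogen on an aromatic carbon of the core, was a 1.0-fold higher number from compound 2 to compound 3 (0.01 log units; within the scatter), and nothing in the measured set points to a move beyond the scatter in this assay for such a change. The expected step from compound 1 to compound 4 is therefore a 1.1-fold lower number from compound 1 to compound 4 (0.04 log units; within the scatter), no more than the scatter. On that basis compound 4 is estimated at 2000 nM, with a range from 1000 nM to 4000 nM in this assay.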

Compound 4, concentration for 50% growth inhibition: 1020 nM
For compound 4 the middle estimate is 2.0-fold (0.29 log units) above the measured one; measured number inside the range.
By their numbers in this assay, from the lowest: compounds 4, 2, 3 and 1 (each within the scatter of the next, the first and the last beyond it).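

Chloro in place of hydrogen, on an aromatic carbon between two ring nitrogen atoms, gave in this assay a 2.1-fold lower number from compound 1 to compound 4 (0.33 log units; beyond the scatter), the first step in this set to pass beyond the scatter. This shows that the position on the core of compound 1 accepts chloro with a modest gain in growth inhibition rather than a loss. The earlier pair showed no movement for this change, yet the two steps cannot be told apart, so no dependence on the core can be claimed: the same change on two cores in this assay, a 1.0-fold higher number (0.01 log units; within the scatter) from compound 2 to compound 3 and a 2.1-fold lower number (0.33 log units; beyond the scatter) from compound 1 to compound 4, 2.2-fold (0.34 log units) apart, within the scatter of two such steps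

The compounds shown leave open whether an amine, a methoxy group or a longer chain at this place would match, exceed or reverse the step with chloro. They also leave open whether the step depends on the chloro group meta to this place.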